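This account rests on a few compounds, and the source may have more. Where it says the series, first, only, none or still open, it means among the compounds named here.

Working notes on the series built on the core of compound 1 `CCc1nn(CCO)c(CC)c1Oc1cc(C)cc(C#N)c1`. Three compounds carry numbers in a physicochemical assay for lipophilicity; a higher number here means a more lipophilic compound, a lower number a more polar compound. In this assay compound 1 gives 3.2, the highest of the three numbers. The nearest of the others is compound 3 `CCc1n[nH]c(CC)c1Oc1cc(C#N)cc(C#N)c1`, which gives 2.8 in this assay, a gap from compound 1 beyond the scatter. The furthest is compound 2 `CCc1nn(CCN)c(CC)c1Oc1cccc(C#N)c1`, which gives 1.2 in this assay, a gap from compound 1 that is also well beyond the scatter. No two of the measured compounds differ in one place only, so no single-point step can be read directly from the measured numbers.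

Compound 4 `CCc1nn(CCO)c(CC)c1Oc1cccc(C#N)c1` has not yet been measured in this assay. Relative to compound 1 it carries one change, (hydrogen in place of methyl on an aromatic carbon), that is, one heavy atom leaves the ring. Within the data shown here, no measured pair isolates this change. The step of a number 0.50 log units lower from compound 1 to compound 4 (beyond the scatter) is expected to be downward and modest, near the edge of the scatter, resting on the number compound 1 gives, 3.2, and the small size of the change. Compound 4 is therefore estimated to give 2.7 in this assay, with a range from 2.3 to 3.1.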

Compound 4, distribution coefficient: 2.7
Estimate against measurement, compound 4: no gap at the digits printed; the range from low to high includes it.
By their numbers in this assay, from the lowest: compound 2; then compounds 4 and 3 (each within the scatter of the next); then compound 1.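

With compound 4, the series gains its first steps that can be read at a single place. In this assay, hydrogen in place of methyl on an aromatic carbon, meta to a cyano group, gives a number 0.50 log units lower from compound 1 to compound 4 (beyond the scatter), so the methyl position alone moves the number beyond the scatter, though the step is modest. At the end of the chain on the aromatic nitrogen, hydroxy in place of amino on a saturated chain carbon gives a number 1.50 log units higher from compound 2 to compound 4 (beyond the scatter), a large step, which shows that this chain position carries far more of the spread among compounds 1, 2 and 4 than the methyl position does. The data shown offer no measurement that explains either step.

Still open, from the compounds shown here alone, is how a carboxylic acid or a longer chain at the chain end would read, and whether a chlorine in place of the methyl would give a step of similar size. Compound 3 differs from every other compound in more than one place, so its steps cannot be read, and neither step above has yet been seen on a second matched pair.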